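From 4-fluorophenyl to 2-(trifluoromethyl)phenyl at the assay limit

The source may report more compounds than this note shows. Statements on the series, on what has been measured and on what is new or still open speak of the compounds shown alone.

Measured in a functional assay on A549 cells (Homo sapiens) for antiproliferative activity, read by MTT assay, with a stated time of 48 h; a lower number here means a stronger inhibitor, a higher number a weaker inhibitor:
compound 1 `C/C(=C\CC/C(C)=C/CC[C@@H]1[C@@]2(C)CCC(=O)C(C)(C)[C@H]2CC[C@@]1(C)O)CC/C=C(\C)C(=O)OCc1cn(-c2ccc(F)cc2)nn1`: > 150000 nM
compound 2 `C/C(=C\CC/C(C)=C/CC[C@@H]1[C@@]2(C)CCC(=O)C(C)(C)[C@H]2CC[C@@]1(C)O)CC/C=C(\C)C(=O)OCc1cn(-c2ccc([N+](=O)[O-])cc2)nn1`: > 150000 nM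
compound 3 `COc1ccccc1-n1cc(COC(=O)/C(C)=C/CC/C(C)=C/CC/C(C)=C/CC[C@@H]2[C@@]3(C)CCC(=O)C(C)(C)[C@H]3CC[C@@]2(C)O)nn1`: > 150000 nM

Each of these three entries is a limit of the assay and not a number. Compound 1 therefore has no exact place in the series, and it shares its position with the other two compounds: the limit of > 150000 nM in this assay, at which 3 of the 3 values shown sit.

The next compound, compound 4 `C/C(=C\CC/C(C)=C/CC[C@@H]1[C@@]2(C)CCC(=O)C(C)(C)[C@H]2CC[C@@]1(C)O)CC/C=C(\C)C(=O)OCc1cn(-c2ccccc2C(F)(F)F)nn1`, keeps the core of compound 1 and changes only the group on the aromatic nitrogen, where 2-(trifluoromethyl)phenyl takes the place of 4-fluorophenyl: 2-(trifluoromethyl)phenyl in place of 4-fluorophenyl on an aromatic nitrogen.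

For the measured compounds named here, three measured steps bear on this change, all of them exchanges at the aryl group. There is a step that the two limits leave unreadable from compound 1 to compound 2. There is a step that the two limits leave unreadable from compound 1 to compound 3. There is a step that the two limits leave unreadable from compound 2 to compound 3. None of them has a size that can be carried over to the new compound.

Compound 3, with 2-methoxyphenyl on that nitrogen, gives > 150000 nM, which is again a limit. No aryl group tested so far has produced a number, so no step beyond the scatter is expected in this assay, and the data support no direction. The expected step is a step that the limit leaves unreadable from compound 1 to compound 4. Compound 4 is estimated at 170000 nM, with an expected range of 70000 nM to 350000 nM, and the assay will most likely report only a limit.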

Compound 4, half-maximal inhibitory concentration: > 150000 nM
Compound 4 was reported as a limit; the forecaster's own chance of this, stated with the estimate: 80%; the middle value is on the limit's open side.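

No step from compound 1, compound 2 or compound 3 to compound 4 can be read, because all four entries are limits of the assay and not numbers: the limit of > 150000 nM in this assay, at which 4 of the 4 values shown sit.

The compounds shown leave open how strongly any of them inhibits these cells, and whether the aryl group on the aromatic nitrogen changes the read-out at all.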